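The compounds below may be only part of what the source reports. "The series", "measured", "known", "first", "only" and "open" are said of these compounds alone.

Measured compounds:
compound 1 `CCOc1ccc(-c2cc3c(ncn3CCN(C)C)c(C#N)n2)cc1C(F)(F)F` gives 32 nM
compound 2 `CCOc1ccc(-c2cc3c(ncn3CCCN(C)C)c(C#N)n2)cc1C(F)(F)F` gives 27 nM
compound 3 `Cn1cnc2c(C#N)nc(-c3ccc(OCc4cccnc4)c(C(F)(F)F)c3)cc21` gives 12.6 nM

Values are from an assay on isolated protein for inhibition of cathepsin S (Homo sapiens), read by fluorescence; a lower number here means a stronger inhibitor, a higher number a weaker inhibitor. Compound 3 stands lowest of the three numbers; compound 2 is nearest to it, compound 1 furthest, and both gaps lie beyond the scatter. For the measured compounds named here, compounds 1 and 2 carry a dimethylamino chain on the shared core; the one measured step between them, a 1.2-fold lower number from compound 1 to compound 2 (0.07 log units; within the scatter), shows that lengthening that chain by one carbon changes little.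

Compound 4 `CN(C)CCCOc1ccc(-c2cc3c(ncn3C)c(C#N)n2)cc1C(F)(F)F` is not yet measured. Relative to compound 3 the change is 2-(dimethylamino)ethyl in place of pyridin-3-yl on a saturated chain carbon bound to an oxygen on an aromatic ring. Going by the values given here, no measured step covers this exchange directly; the chain-length step from compound 1 to compound 2 sits at a different position and only indicates that a dimethylamino chain is tolerated, with the numbers of compounds 1 and 2 standing not far above that of compound 3. Among the compounds with values here, with the dimethylamino chain now on the ether oxygen and no counterpart among the measured compounds, the expected step of a 1.7-fold higher number from compound 3 to compound 4 (0.24 log units; within the scatter) in this assay is small, within scatter to modestly weaker, leaning to a somewhat higher number. Compound 4 is therefore estimated at 22 nM, with a range from 8 nM to 60 nM.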

Compound 4, half-maximal inhibitory concentration: 41 nM
Compound 4: the middle estimate sits 1.9-fold (0.27 log units) below what was measured; the range from low to high includes it.
By their numbers in this assay, from the lowest: compound 3; then compounds 2, 1 and 4 (each within the scatter of the next).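

In this assay the group on the saturated chain carbon bound to the ether oxygen is not indifferent: 2-(dimethylamino)ethyl in place of pyridin-3-yl gives a 3.3-fold higher number from compound 3 to compound 4 (0.51 log units; beyond the scatter), a modest step beyond the scatter. For the compounds shown here, the dimethylamino chains seen earlier sat at a different place, where the only step read a 1.2-fold lower number from compound 1 to compound 2 (0.07 log units; within the scatter), so this is the sole reading at the ether position; it shows that the pyridin-3-yl group is preferred there over this open chain, while compound 4 at 41 nM shows that the 3-(dimethylamino)propoxy group is still accepted at a modest cost. No supporting data accompany this step, so the series offers no explanation for its size.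

The single exchange removes a ring and brings in a dimethylamino group at once, so the compounds shown cannot say which of the two changes sets the step; a phenyl group or a morpholine ring at the same place would separate them. Also open, on these data alone, is how the step depends on chain length at this position, which a shorter 2-(dimethylamino)ethoxy group would address.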